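Pyridyl for methylphenyl on the sulfur

The source may report more compounds than this note shows. Statements on the series, on what has been measured and on what is new or still open speak of the compounds shown alone.

Compound 1 (`Cc1ccc(SCc2ccc(/C=C/C(=O)Nc3ccccc3N)cc2)cc1`) gives 22% in a functional assay on SMMC-7721 cells (Homo sapiens) for inhibition, read by CCK-8 assay, with a stated time of 72 h, tested at 2 uM; a higher number here means more inhibition of growth at the concentration tested, a lower number less inhibition of growth. Compound 3 (`CC(C)(C)c1ccc(SCc2ccc(C(=O)Nc3ccccc3N)cc2)cc1`) gives 23.6% and compound 2 (`COc1ccc(SCc2ccc(/C=C/C(=O)Nc3ccccc3N)cc2)cc1OC`) gives 14.3% in this assay. The number for compound 1 is the second highest of the three, but every gap among them is within the scatter. Going by the values given here, the one measured step at the sulfur is a number 7.7 percentage points lower from compound 1 to compound 2 (within the scatter). Compound 4 (`Nc1ccccc1NC(=O)/C=C/c1ccc(CSc2ccc(C(F)(F)F)cn2)cc1`) differs from compound 1 thus: 5-(trifluoromethyl)pyridin-2-yl in place of 4-methylphenyl on a sulfur. Among the compounds with values here, no measured compound carries a trifluoromethyl group or a nitrogen in the ring on the sulfur, so the step from compound 1 to compound 2 is the only guide, and it stayed within scatter. Compound 4 is therefore expected to show a number 2 percentage points lower from compound 1 to compound 4 (within the scatter). The estimate for compound 4 is 20%, with a range from 8% to 34%.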

Compound 4, percent growth inhibition at one concentration: 12.1%
Beside the measured number, compound 4's estimate is 7.9 percentage points above it; the measured number falls inside the stated range.
By their numbers in this assay, from the lowest: compounds 4, 2, 1 and 3 (each within the scatter of the next, the first and the last beyond it).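

Working notes: in this assay, replacing a carbon-only ring on the sulfur with one holding a nitrogen and a trifluoromethyl group gives a number 9.9 percentage points lower from compound 1 to compound 4 (within the scatter), and the comparison with the dimethoxy analogue gives a number 2.2 percentage points lower from compound 2 to compound 4 (within the scatter). The 4-methylphenyl, 3,4-dimethoxyphenyl and 5-(trifluoromethyl)pyridin-2-yl groups thus all lie within the scatter of one another, and no change on this sulfur has yet moved the number beyond it. Nothing available bears on the reason for these numbers.

As far as these compounds go, the ring nitrogen and the trifluoromethyl group enter together in compound 4, so their separate contributions stay open. Also open, from the compounds shown here alone, is whether a plain pyridin-2-yl group, or a ring carrying a carboxylic acid or an amine, would give a step beyond the scatter.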